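The source may report more compounds than this note shows. Statements on the series, on what has been measured and on what is new or still open speak of the compounds shown alone.

Working notes on the hydroxamic acid series in an ADME assay on Huh-7 cells (Homo sapiens) for cytotoxicity, read by MTT assay, with a stated time of 72 h; on this read-out lower numbers stand for higher toxicity in this test and higher numbers for lower toxicity in this test.

Three measured points open the set. Compound 1 `COc1ccccc1/C(N)=N/O` is reported only as a limit: in this assay compound 1 gives > 800000 nM, which is a limit of the measurement and not a number. Compound 2 `O=C(NO)c1ccccc1Cl` gives 330000 nM in this assay. Compound 3 `Cc1cccc(C(=O)NO)c1` gives 340000 nM in this assay. Of the two numbers that are not limits, compound 2 and compound 3 sit within the scatter of one another, so neither can be set apart from the other on this read-out; the third value is the limit noted for compound 1 (the limit of > 800000 nM in this assay, at which 1 of the 3 values shown sits).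

Among the measured compounds shown here, no pair of measured compounds differs in a single place, so no measured step is available as a guide.

Compound 4 `CCCCOc1ccccc1C(=O)NO` is the next member to be measured. It differs from compound 2 as butoxy in place of chloro on an aromatic carbon. With nothing in the measured set to show how such a change acts in this assay, the expected step from compound 2 to compound 4 is no change at the digits printed from compound 2 to compound 4 (within the scatter), none beyond the scatter. On that basis compound 4 is estimated to give 330000 nM in this assay, with a range from 130000 nM to 800000 nM.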

Compound 4, half-maximal cytotoxic concentration: 380000 nM
Estimate against measurement, compound 4: 1.2-fold (0.06 log units) below; low and high end bracket the measured number.
By their numbers in this assay, from the lowest: compounds 2, 3 and 4 (each within the scatter of the next). At a limit, above all of these: compound 1.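

Butoxy in place of chloro on an aromatic carbon of a six-membered aromatic ring of carbon only, ortho to a group of 4 heavy atoms, gives in this assay a 1.2-fold higher number from compound 2 to compound 4 (0.06 log units; within the scatter). Among the compounds shown here, this is the first measured single-place step, and it gives this position a reading that the earlier compounds could not: the change brings in 5 heavy atoms for 1, with 1 hydrogen-bond acceptor entering and none leaving, and the two compounds cannot be set apart on this read-out. This holds for this one pair only and does not yet describe the position as a whole, and compound 1 stays outside the comparison as a limit and not a number: the limit of > 800000 nM in this assay, at which 1 of the 4 values shown sits.

As far as these compounds go, whether an amine, a carboxylic acid or a chain longer than butoxy at this same place would give a step beyond the scatter remains open. Also open, from the compounds shown here alone, is whether butoxy in place of chloro would read the same way at another aromatic carbon, since a single step at a single place cannot settle that.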